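From ethylcarbamoyl to carbamoyl: a step among limits

A few compounds are considered here, and "the series" means these few. Any claim that something is new, unique, unknown or untested is made for them only; others in the source may bear on it.

Measured in a physicochemical assay for solubility (on this read-out lower numbers stand for lower solubility and higher numbers for higher solubility), each value a limit and not a number:
- compound 1 `CCNC(=O)c1cc(C(=O)NC)c(=O)n(Cc2ccccc2)c1` gives >= 144 ug/mL
- compound 2 `CNC(=O)c1cc(C(=O)NC2CC2)cn(Cc2cccc(F)c2)c1=O` gives >= 133 ug/mL
- compound 3 `CNC(=O)c1cc(C(=O)NC2CC2)cn([C@H](C)c2ccccc2)c1=O` gives >= 168 ug/mL

Compound 1 therefore stands at a limit, as do the other two compounds, and no rank can be read among them. Compound 4 `CNC(=O)c1cc(C(N)=O)cn(Cc2ccccc2)c1=O` carries hydrogen in place of ethyl on an amide-type nitrogen and is still unmeasured. Among the compounds with values here, the one measured step, a step that the two limits leave unreadable from compound 2 to compound 3, lies in a different group and offers no size to carry over. No step beyond the scatter is therefore expected in this assay, and no direction is expected either. The estimated step that the limit leaves unreadable from compound 1 to compound 4 is accordingly small. Compound 4 is expected at 160 ug/mL, with an estimated range from 80 ug/mL to 320 ug/mL as its bounds.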

Compound 4, solubility: 71 ug/mL
Estimate against measurement, compound 4: 2.3-fold (0.35 log units) above, and the stated range ends above it.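

Hydrogen in place of ethyl on the amide-type nitrogen gives an at least 2.0-fold lower number from compound 1 to compound 4 (0.30 log units; that floor lies within the scatter) in this assay. Compound 4, at 71 ug/mL, is the only compound shown that gives a number and not a limit, so this change is the only one here with a readable direction. The size of the step remains a floor, and compound 1 stands at a limit: the limit of >= 144 ug/mL in this assay, at which 1 of the 4 values shown sits.

From the compounds shown here alone, whether the true step lies beyond the scatter stays open. The compounds shown also leave open how a propyl chain on this nitrogen, or a carboxylic acid in place of the carbamoyl, would read in this assay.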